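The source may report more compounds than this note shows. Statements on the series, on what has been measured and on what is new or still open speak of the compounds shown alone.

In a functional assay on A549 cells (Homo sapiens) for antiproliferative activity, read by MTT assay, with a stated time of 48 h (on this read-out higher numbers stand for weaker inhibition and lower numbers for stronger inhibition), two compounds have been measured so far. Compound 1 `Cn1cc(C2=C(c3nn(CCCn4cccc4)c4ncccc34)C(=O)NC2=O)c2ccccc21` gives > 100000 nM, which is a limit of the assay and not a number. Compound 2 `CN(C)CCCn1nc(C2=C(c3cn(C)c4ccccc34)C(=O)NC2=O)c2cccnc21` gives > 100000 nM, also a limit. Compound 2 thus sits at the limit of > 100000 nM in this assay, at which 2 of the 2 values shown sit. For the measured compounds named here, the only measured step, a step that the two limits leave unreadable from compound 1 to compound 2, puts dimethylamino in place of 1H-pyrrol-1-yl on the chain, and it offers no size to carry forward. Compound 3 `Cn1cc(C2=C(c3n[nH]c4ncccc34)C(=O)NC2=O)c2ccccc21` has hydrogen in place of 3-(dimethylamino)propyl on an aromatic nitrogen. Going by the values given here, no measured step removes this chain, so the direction rests on little, and at most a modest gain in inhibition is expected. The expected change is an at least 2.5-fold lower number from compound 2 to compound 3 (0.39 log units; beyond the scatter), and it may remain unreadable. For compound 3 the estimated value is 40000 nM, with an estimated range from 8000 nM to 100000 nM.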

Compound 3, half-maximal inhibitory concentration: > 100000 nM
Compound 3: only a limit was reported (the forecaster's own chance of this, stated with the estimate: 45%); middle value at least 2.5-fold (0.39 log units) from the limit.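

In this assay compound 3 gives > 100000 nM, a limit and not a number, so its steps from compound 1 and compound 2 cannot be read. All three share one limit: the limit of > 100000 nM in this assay, at which 3 of the 3 values shown sit. The compounds shown leave open which change, if any, would give a readable value.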